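A few compounds are considered here, and "the series" means these few. Any claim that something is new, unique, unknown or untested is made for them only; others in the source may bear on it.

Measured compounds in a functional assay on cells (Oocyte) for inhibition of Voltage-dependent T-type calcium channel subunit alpha-1H (Homo sapiens), tested at 100 uM; a higher number here means more inhibition at the concentration tested (going by the name of the read-out), a lower number less inhibition:
- compound 1 `COC(=O)CC1c2ccccc2N=C(N2CCOCC2)N1c1ccccc1`: 14%
- compound 2 `O=C(O)CC1c2ccccc2N=C(N2CCOCC2)N1c1ccccc1`: 9%
- compound 3 `O=C(CC1c2ccccc2N=C(N2CCCCC2)N1c1ccccc1)NCc1ccccc1`: 77%

Compound 3 stands highest of the three, its gap to compound 1 and to compound 2 lying beyond the scatter in each case. For the measured compounds named here, the only single-place step among the measured compounds is a number 5 percentage points lower from compound 1 to compound 2 (within the scatter), which concerns the ester-to-acid change and not the ring on the carbon with a double bond to nitrogen.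

Compound 4 `O=C(CC1c2ccccc2N=C(N2CCOCC2)N1c1ccccc1)NCc1ccccc1` is the next compound. Its change from compound 3: morpholin-4-yl in place of piperidin-1-yl on a carbon with a double bond to nitrogen. Going by the values given here, no measured pair isolates this change. Compound 1 and compound 2 carry the morpholin-4-yl group and give low values, but they also lack the (benzylcarbamoyl)methyl group of compound 3, so their gap to compound 3 cannot be assigned to the ring alone. The direction and size of the step in this assay are therefore open; a fall from compound 3 is plausible, but a value near compound 3 cannot be excluded.

The expected step is a number 27 percentage points lower from compound 3 to compound 4 (beyond the scatter), a moderate fall as the estimate, with a wide range. Compound 4 is estimated at 50%, with a range from 15% to 80%.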

Compound 4, a percentage reported as inhibition, at one concentration (the size of the read-out at that concentration, not a potency): 63.8%
Compound 4: the middle estimate sits 13.8 percentage points below what was measured, and the stated range covers the measured number.
By their numbers in this assay, from the lowest: compounds 2 and 1 (each within the scatter of the next); then compound 4; then compound 3.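

In this assay the exchange at the carbon with a double bond to nitrogen now has a measured pair: morpholin-4-yl in place of piperidin-1-yl gives a number 13.2 percentage points lower from compound 3 to compound 4 (beyond the scatter) and is a modest step, and compound 4 still reaches 63.8% with the morpholin-4-yl group in place. The low values of compound 1 and compound 2 therefore do not follow from morpholin-4-yl alone, as the large steps sit on the carbonyl carbon: benzylamino in place of hydroxy gives a number 54.8 percentage points higher from compound 2 to compound 4 (beyond the scatter) and benzylamino in place of methoxy gives a number 49.8 percentage points higher from compound 1 to compound 4 (beyond the scatter) with the morpholin-4-yl group unchanged. No measurement shown here gives a reason for either the modest step or the large ones.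

The compounds shown cover only two groups at the carbon with a double bond to nitrogen, so a pyrrolidin-1-yl or a 4-methylpiperazin-1-yl group there remains an open case. On the carbonyl carbon only benzylamino stands for the amides, which leaves open whether a shorter methylamino or a longer 2-phenylethylamino group would hold the gain.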